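This account rests on a few compounds, and the source may have more. Where it says the series, first, only, none or still open, it means among the compounds named here.

Measured so far:
- Compound 1 `CCC(=O)N[C@@H]1CCCc2c1cncc2N1Cc2cc(Cl)ccc2C1=O` gives 28 nM in an assay on cells for inhibition of cytochrome P450 11B2, mitochondrial (Homo sapiens), read by HTRF; on this read-out higher numbers stand for weaker inhibition and lower numbers for stronger inhibition.
- Compound 2 `CCS(=O)(=O)N1CC2(CN(c3cncc(N4C(=O)c5ccc(Cl)cc5C4(C)C)c3)C2)C1` gives 16 nM in this assay.

Of these two numbers, compound 1 has the higher one, but compound 2 lies close enough that the gap between them falls within the ordinary scatter of repeated measurements, so the two stand level on this evidence. Compound 3 `CCC(=O)N[C@@H]1CCCc2c1cncc2N1C(=O)c2ccc(Cl)cc2[C@H]1C` has not yet been measured. It differs from compound 1 in a single place: methyl in place of hydrogen on a saturated ring carbon. Going by the values given here, no pair of measured compounds shares exactly this change, so nothing here shows how large its effect is on its own. The expectation is a small step in this assay, toward a somewhat lower number, not clearly beyond the scatter. Compound 3 is therefore estimated at 20 nM, with a likely range from 8 nM to 60 nM. That estimate corresponds to an expected step of a 1.4-fold lower number from compound 1 to compound 3 (0.15 log units; within the scatter).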

Compound 3, half-maximal inhibitory concentration: 66 nM
Estimate against measurement, compound 3: 3.3-fold (0.52 log units) below; the measured number lies above the stated range.
By their numbers in this assay, from the lowest: compounds 2 and 1 (each within the scatter of the next); then compound 3.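

In this assay, methyl in place of hydrogen on this saturated ring carbon, next to the ring nitrogen, gives a 2.4-fold higher number from compound 1 to compound 3 (0.37 log units; beyond the scatter), which stands for weaker inhibition. This is the only change in a single place among the compounds shown, and it reveals that this position is sensitive to the addition of just one carbon, with the number moving in the unfavourable direction. No measurement shown here bears on the reason for this step.

On these data alone, whether a longer chain such as ethyl, or a hydroxyl group or a fluorine atom, would shift the number further at this carbon remains open. So does whether methyl with the opposite spatial arrangement at this carbon would give the same result, and whether this step would recur on a different core.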